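Chloro in place of methoxy: expecting compound 4

The compounds below may be only part of what the source reports. "The series", "measured", "known", "first", "only" and "open" are said of these compounds alone.

Measured in a functional assay on MCF7 cells (Homo sapiens) for cytotoxicity, read by MTT assay, with a stated time of 48 h; a higher number here means a weaker inhibitor, a lower number a stronger inhibitor:
Compound 1 `CCN(CC)C(=S)SC(CC(=O)c1ccccc1)c1ccc(F)cc1`: 700 nM
Compound 2 `CCN(CC)C(=S)SC(CC(=O)c1ccccc1)c1ccccc1Cl`: 4500 nM
Compound 3 `CCN(CC)C(=S)SC(CC(=O)c1ccc(OC)cc1)c1ccccc1`: 4500 nM

In this assay, compound 2 and compound 3 stand level at 4500 nM, together the highest of the three numbers. Compound 4 `CCN(CC)C(=S)SC(CC(=O)c1ccc(Cl)cc1)c1ccccc1` has chloro in place of methoxy on an aromatic carbon. For the measured compounds named here, the only measured step, a 6.4-fold higher number from compound 1 to compound 2 (0.81 log units; beyond the scatter), lies at another place, and no measured step replaces methoxy. It shows that one change can move the number beyond the scatter, but it gives no direction here. No step beyond the scatter is therefore expected, and the estimated step is a 1.5-fold lower number from compound 3 to compound 4 (0.18 log units; within the scatter). Compound 4 is estimated at 3000 nM, within a range of 800 nM to 9000 nM.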

Compound 4, half-maximal inhibitory concentration: 40 nM
Compound 4: middle estimate off by 75-fold (1.88 log units), on the high side, outside the stated range (below it).
By their numbers in this assay, from the lowest: compound 4; then compound 1; then compounds 2 and 3 (each within the scatter of the next).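

In this assay, chloro in place of methoxy on an aromatic carbon, para to a large group, gives a 110-fold lower number from compound 3 to compound 4 (2.05 log units; beyond the scatter). The earlier compounds shown here held no step at this position, and this one shows that the number responds strongly to the group placed there. Nothing available accounts for the size of this step.

The compounds shown leave open whether the step is particular to chloro or would also appear with bromo, trifluoromethyl or an amine on the same aromatic carbon. They also leave open whether the unsubstituted phenyl would stand nearer to compound 3 or to compound 4.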